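The source may hold more compounds than are shown below. What is called first, only, known or untested is meant among the compounds shown, and "the series" means these compounds.

Compound 1 `COc1ccc(C(=O)NC(=S)N2CCc3c(OCCCCCOc4ccc(Cl)cc4)cccc32)cc1` and compound 2 `O=C(NC(=S)N1CCc2c(OCCCCCOc3ccc(Cl)cc3)cccc21)c1ccsc1` share one core and differ only in the ring attached to the carbonyl carbon. In an ADME assay on Huh-7 cells (Homo sapiens) for cytotoxicity (a higher number here means that more compound is tolerated, a lower number that less compound is tolerated), compound 1 gives 34400 nM. Compound 2 reaches only a limit of this assay, > 50000 nM, so its true value is not known. The change from compound 1 to compound 2 an at least 1.4-fold higher number from compound 1 to compound 2 (0.16 log units; that floor lies within the scatter) is therefore also only a floor, set by the limit of > 50000 nM in this assay, at which 1 of the 2 values shown sits.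

Compound 3 `O=C(NC(=S)N1CCc2c(OCCCCCOc3ccc(Cl)cc3)cccc21)c1cccnc1` is built from compound 2 by the change (pyridin-3-yl in place of thiophen-3-yl on a carbonyl carbon), so it differs from compound 2 in one place. Among the measured compounds shown here, of the measured steps, only the one from compound 1 to compound 2 bears on this change, since it also swaps the ring on the carbonyl carbon, and it showed no step beyond the scatter. The step from compound 2 to compound 3 a number no higher from compound 2 to compound 3 (the limit leaves the size open) is therefore expected to stay within the scatter. Compound 3 is expected to sit near 50000 nM, within about 30000 nM to 100000 nM in this assay, and it may well again reach only a limit.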

Compound 3, half-maximal cytotoxic concentration: 11100 nM
Compound 3: the middle estimate sits 4.5-fold (0.65 log units) above what was measured, and the stated range ends above it.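

The ring on the carbonyl carbon matters in this assay, which the earlier pair could not show: pyridin-3-yl in place of thiophen-3-yl gives an at least 4.5-fold lower number from compound 2 to compound 3 (0.65 log units; beyond the scatter). Pyridin-3-yl in place of 4-methoxyphenyl gives a 3.1-fold lower number from compound 1 to compound 3 (0.49 log units; beyond the scatter), the first step here with a measured number at both ends, and together the two steps make compound 3 the compound of the three at which the least is tolerated. Compound 2 stands at a limit, so the step that starts from it gives only a floor and its true size remains unknown: the limit of > 50000 nM in this assay, at which 1 of the 3 values shown sits.

The swap from thiophen-3-yl to pyridin-3-yl changes the ring size and the hetero atom together, so these compounds cannot tell which of the two goes with the lower number. An unsubstituted phenyl ring or a pyridin-4-yl ring on the same carbonyl carbon would help separate the effect of the ring nitrogen from that of the ring itself, and would show whether the place of that nitrogen within the ring counts.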